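This account rests on a few compounds, and the source may have more. Where it says the series, first, only, none or still open, it means among the compounds named here.

Measured compounds:
- compound 1, `CC(C)=CC[C@@H](OC[C@@H](C)O)C1=CC(=O)c2c(O)ccc(O)c2C1=O`: in a functional assay on HeLa cells (Homo sapiens) for cytotoxicity, read by MTT assay (a lower number here means a stronger inhibitor, a higher number a weaker inhibitor), compound 1 gives 22500 nM
- compound 2, `CC[C@](C)(O)CC(=O)O[C@H](CC=C(C)C)C1=CC(=O)c2c(O)ccc(O)c2C1=O`: in this assay compound 2 gives 30200 nM
- compound 3, `CCCC(CC(=O)O[C@H](CC=C(C)C)C1=CC(=O)c2c(O)ccc(O)c2C1=O)OC(C)=O`: in this assay compound 3 gives 51200 nM

Compound 2 stands second highest of the three numbers; its nearest neighbour is compound 1, its furthest compound 3, and both gaps are within the scatter. Compound 4, `CC(C)=CC[C@@H](OC(=O)C1CCCOC1)C1=CC(=O)c2c(O)ccc(O)c2C1=O`, differs from compound 2 as follows: oxan-3-yl in place of 2-hydroxy-2-methylbutyl on a carbonyl carbon. Among the measured compounds shown here, two measured steps bear on this part of the molecule: a 1.3-fold higher number from compound 1 to compound 2 (0.13 log units; within the scatter) and a 1.7-fold higher number from compound 2 to compound 3 (0.23 log units; within the scatter). Neither reaches beyond the scatter, so exchanging the group on the carbonyl carbon has so far left this assay essentially unchanged. For compound 4 no step beyond the scatter is therefore expected: a 1.0-fold lower number from compound 2 to compound 4 (0.00 log units; within the scatter). Compound 4 is estimated at 30000 nM in this assay, with a range of 12000 nM to 75000 nM.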

Compound 4, half-maximal inhibitory concentration: 60500 nM
The estimate for compound 4 lay 2.0-fold (0.30 log units) below the measured number; low and high end bracket the measured number.
By their numbers in this assay, from the lowest: compounds 1, 2, 3 and 4 (each within the scatter of the next, the first and the last beyond it).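

Putting oxan-3-yl in place of 2-hydroxy-2-methylbutyl on the carbonyl carbon gives a 2.0-fold higher number from compound 2 to compound 4 (0.30 log units; within the scatter) and stays within the scatter, as does a 1.2-fold higher number from compound 3 to compound 4 (0.07 log units; within the scatter). Only a 2.7-fold higher number from compound 1 to compound 4 (0.43 log units; beyond the scatter) in this assay goes beyond the scatter, a modest step and the first in the series to do so, which shows that a change on this oxygen can shift the number. No measurement at hand offers an explanation for this shift.

On these data alone, what a cyclohexyl or piperidin-3-yl group in place of oxan-3-yl on the carbonyl carbon would give remains open. So does the effect of a carboxylic acid or a longer chain there.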